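Toward a Formylamino Analogue: Expectation Before Measurement

The source may hold more compounds than are shown below. What is called first, only, known or untested is meant among the compounds shown, and "the series" means these compounds.

Compound 1, `Cc1nc2c(OCc3ccccc3)cccn2c1N`: 99%
Compound 2, `CCCc1nc2c(OCc3ccccc3)cccn2c1N`: 31%
Compound 3, `Cc1nc2c(OCc3ccccc3)cccn2c1CN`: 46%

Of the compounds shown here, three on a shared core have been tested in a functional assay on the whole organism with Rattus norvegicus as the target, at a dose of 40 mg/kg by the intraperitoneal route; a higher number here means more inhibition at the dose given (going by the name of the read-out), a lower number less inhibition. Compound 1 gives 99%, compound 2 gives 31% and compound 3 gives 46%. Compound 3 thus stands second highest of the three: its nearest neighbour is compound 2, whose number is lower by a gap beyond the scatter, and the furthest is compound 1, whose number is higher, again beyond the scatter.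

Compound 4, `Cc1nc2c(OCc3ccccc3)cccn2c1NC=O`, has not yet been measured. It differs from compound 3 in one place:
formylamino in place of aminomethyl on an aromatic carbon

Neither measured step covers this change directly. The two known steps both start from compound 1: a number 68 percentage points lower from compound 1 to compound 2 (beyond the scatter) and a number 53 percentage points lower from compound 1 to compound 3 (beyond the scatter). Each is large and downward. Compound 4 carries formylamino where compound 1 carries amino, and compound 3 showed that moving from amino to aminomethyl cost a great deal. Within the data shown here, the only guidance is that altering this group away from amino has so far lowered inhibition, which gives no firm direction for a further move from aminomethyl to formylamino. The step is therefore expected to be a number 1 percentage points lower from compound 3 to compound 4 (within the scatter), not clearly beyond the scatter in either direction, with a wide range. Compound 4 is estimated at 45% in this assay, with a range from 15% to 80%.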

Compound 4, a percentage reported as inhibition, in the whole organism at one dose (the size of the read-out at that dose, not a potency): 49%
Compound 4: the middle estimate sits 4 percentage points below what was measured; the measured number falls inside the stated range.
By their numbers in this assay, from the lowest: compound 2; then compounds 3 and 4 (each within the scatter of the next); then compound 1.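

In this assay, formylamino in place of aminomethyl on the aromatic carbon of the five-membered ring is a number 3 percentage points higher from compound 3 to compound 4 (within the scatter) and so does not separate these two groups at this dose. Formyl on the nitrogen of compound 1 keeps that nitrogen bound to the ring, yet the step is a number 50 percentage points lower from compound 1 to compound 4 (beyond the scatter) and is of a size with a number 53 percentage points lower from compound 1 to compound 3 (beyond the scatter), which shows that the earlier loss does not depend on a carbon being placed between the ring and the nitrogen. Among the compounds shown, the unsubstituted amino group of compound 1 therefore stands apart from both replacements at this position, and neither compound 3 nor compound 4 goes against this.

What the compounds leave open is whether a smaller substituent on that nitrogen, such as methylamino, keeps more of the inhibition than formyl does, and whether acetylamino behaves like formylamino. Since each figure is a read-out at a single dose, and no measurement shown here bears on why either replacement lowers the number, the reason for these steps remains unknown.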